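The source may hold more compounds than are shown below. What is called first, only, known or untested is meant among the compounds shown, and "the series" means these compounds.

In a functional assay on KG-1 cells (Homo sapiens) for cytotoxicity, read by luminescence and CellTiter-Glo, with a stated time of 3 days (a higher number here means a weaker inhibitor, a lower number a stronger inhibitor), compound 1 `O=C(Nc1ccc(OC(F)(F)F)c(Cl)c1)c1cc(F)ccc1O` gives 370 nM and compound 2 `O=C(Nc1ccc(Cl)c(Cl)c1)c1cc(F)ccc1O` gives 760 nM, so compound 2 has the higher number of the two. Compound 3 `O=C(Nc1ccc(Br)c(Cl)c1)c1cc(F)ccc1O` is not yet measured. It differs from compound 2 by bromo in place of chloro on an aromatic carbon, ortho to a chloro group: bromo in place of chloro on an aromatic carbon. For the measured compounds named here, the only measured step at this site is modest: a 2.1-fold higher number from compound 1 to compound 2 (0.31 log units; beyond the scatter). Going by the values given here, it involves no bromo compound, so only a small move toward a lower number is expected. The estimated change is a 1.4-fold lower number from compound 2 to compound 3 (0.14 log units; within the scatter). Compound 3 is expected at 550 nM, within an estimated range of 270 nM to 1100 nM.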

Compound 3, half-maximal inhibitory concentration: 670 nM
For compound 3 the middle estimate is 1.2-fold (0.09 log units) below the measured one; low and high end bracket the measured number.
By their numbers in this assay, from the lowest: compounds 1, 3 and 2 (each within the scatter of the next, the first and the last beyond it).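

Bromo brings a third group to this position, and the steps of a 1.1-fold lower number from compound 2 to compound 3 (0.05 log units; within the scatter) and a 1.8-fold higher number from compound 1 to compound 3 (0.26 log units; within the scatter) set it apart from neither neighbouring compound. So bromo cannot be told from chloro or from trifluoromethoxy here, even though those two differ from each other beyond the scatter. Nothing measured here offers a reason for these numbers.

Still open, going by these compounds, is whether a different kind of group at this position, such as an amine, a carboxylic acid or a longer chain, would shift the number beyond the scatter. Also open, on these data alone, is whether bromo and chloro would stay this close with other groups on the shared core.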